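A few compounds are considered here, and "the series" means these few. Any claim that something is new, unique, unknown or untested is made for them only; others in the source may bear on it.

Measured in an ADME assay on microsomes from liver (Homo sapiens) for metabolic stability, read by LC-MS, using NADPH, with stated times of 10 min and 30 min (on this read-out lower numbers stand for slow clearance and higher numbers for fast clearance), each value a limit:
- Compound 1 `CCC(=O)N[C@@H]1CCCc2c1cncc2N1C(=O)c2ccc(Cl)cc2[C@@H]1CC`: < 3.5 mL/min/kg
- Compound 2 `CC(=O)N[C@@H]1CCCc2c1cncc2N1C(=O)c2ccc(Cl)cc2[C@H]1C`: < 3.5 mL/min/kg
- Compound 3 `CCC(=O)N[C@@H]1CCCc2c1cncc2N1Cc2cc(Cl)ccc2C1=O`: < 3.5 mL/min/kg

Compound 3 gives only a limit, < 3.5 mL/min/kg, and no number. The three compounds stand together: the limit of < 3.5 mL/min/kg in this assay, at which 3 of the 3 values shown sit.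

Compound 4 `CCC(=O)N[C@@H]1CCCc2c1cncc2N1C(=O)c2ccc(Cl)cc2[C@H]1C` differs from compound 3 by methyl in place of hydrogen on a saturated ring carbon.

Among the measured compounds shown here, the one measured step with a change at a saturated ring carbon is a step that the two limits leave unreadable from compound 1 to compound 3, and its size cannot be read. On that step, no change beyond the usual scatter is expected in this assay, and no direction can be given. The expected step is a number no lower from compound 3 to compound 4 (the limit leaves the size open).

For compound 4 the estimate is 3.5 mL/min/kg, with an expected range of 2.5 mL/min/kg to 6 mL/min/kg.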

Compound 4, clearance: < 3.5 mL/min/kg
Compound 4: only a limit was reported; the forecaster's own chance of this, stated with the estimate: 80%; the middle value lies on the limit itself.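

Among the compounds shown here, no step to compound 4 from compound 2 or compound 3 can be read in this assay, as each pair rests on limits alone. The compounds shown leave open the actual clearance of each compound and whether methyl in place of hydrogen on a saturated ring carbon changes it.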